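Trifluoromethyl for Methyl on the Triazole-Bound Aryl Ring

This account rests on a few compounds, and the source may have more. Where it says the series, first, only, none or still open, it means among the compounds named here.

In a functional assay on Caco-2 cells (Homo sapiens) for antiproliferative activity, read by MTT assay, with a stated time of 72 h (on this read-out lower numbers stand for stronger inhibition and higher numbers for weaker inhibition), the three measured compounds gave:
Compound 1 `COc1cc(/C=C/C(=O)OCCSc2nc(-c3ccc(S(C)(=O)=O)cc3)n(-c3ccc(Br)cc3)n2)ccc1OC(C)=O`: 12100 nM
Compound 2 `COc1cc(/C=C/C(=O)OCCSc2nc(-c3ccc(S(C)(=O)=O)cc3)n(-c3ccc(F)cc3)n2)ccc1OC(C)=O`: 10800 nM
Compound 3 `COc1cc(/C=C/C(=O)OCCSc2nc(-c3ccc(S(C)(=O)=O)cc3)n(-c3ccc(C)cc3)n2)ccc1OC(C)=O`: 14100 nM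

Compound 3 holds the highest of the three numbers, but it is not set apart: the step of a 1.2-fold higher number from compound 1 to compound 3 (0.07 log units; within the scatter) and the step of a 1.3-fold higher number from compound 2 to compound 3 (0.12 log units; within the scatter) both lie within the scatter, as does the step of a 1.1-fold lower number from compound 1 to compound 2 (0.05 log units; within the scatter) between the other two. Three different groups on that aromatic carbon thus gave numbers that cannot be told apart.

Compound 4, `COc1cc(/C=C/C(=O)OCCSc2nc(-c3ccc(S(C)(=O)=O)cc3)n(-c3ccc(C(F)(F)F)cc3)n2)ccc1OC(C)=O`, carries the change (trifluoromethyl in place of methyl on an aromatic carbon). Among the measured compounds shown here, no measured step involves a trifluoromethyl, so the closest guides are the three swaps already seen at this position, each of which stayed within the scatter. On that basis the step of a 1.1-fold lower number from compound 3 to compound 4 (0.05 log units; within the scatter) is expected to be no larger than the scatter, in no settled direction. Compound 4 is therefore estimated at 12500 nM, with a range from 6500 nM to 25000 nM in this assay.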

Compound 4, half-maximal inhibitory concentration: 10800 nM
For compound 4 the middle estimate is 1.2-fold (0.06 log units) above the measured one, within the range that was stated.
By their numbers in this assay, from the lowest: compounds 2, 4, 1 and 3 (each within the scatter of the next).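

Trifluoromethyl brings more heavy atoms to this aromatic carbon than any group seen there before, yet in this assay the step of a 1.3-fold lower number from compound 3 to compound 4 (0.12 log units; within the scatter) stays within the scatter, as do the step of no change at the digits printed from compound 2 to compound 4 (within the scatter) and the step of a 1.1-fold lower number from compound 1 to compound 4 (0.05 log units; within the scatter) from the other two compounds. Four groups at this position, from fluoro to trifluoromethyl, now give numbers that cannot be told apart, so the change from 4-methylphenyl to 4-(trifluoromethyl)phenyl extends this flat picture to a group of several heavy atoms. Nothing at hand accounts for this flat picture.

Still open, from the compounds shown here alone, is whether an amine, a carboxylic acid or a longer chain on this carbon would give a number that stands apart from these four. Also open, going by these compounds, is whether the same four groups would stay indistinguishable on cells other than those of this assay.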